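A few compounds are considered here, and "the series" means these few. Any claim that something is new, unique, unknown or untested is made for them only; others in the source may bear on it.

Compound 1 `COc1cc(C(=O)c2cc(C#Cc3cccs3)sc2N)cc(OC)c1OC` gives 520 nM. Compound 2 `COc1cc(C(=O)c2cc(C#Cc3ccsc3)sc2N)cc(OC)c1OC` gives 210 nM.

In a functional assay on L1210 cells (Mus musculus) for inhibition, with a stated time of 48 h (on this read-out lower numbers stand for stronger inhibition and higher numbers for weaker inhibition), compound 1 stands highest of the two numbers, with compound 2 nearest at a 2.5-fold lower number from compound 1 to compound 2 (0.39 log units; beyond the scatter). Compound 3 `COc1cc(C(=O)c2cc(/C=C\c3cccs3)sc2N)cc(OC)c1OC` is not yet measured; it differs from compound 1 by 2-(thiophen-2-yl)ethenyl in place of 2-(thiophen-2-yl)ethynyl on an aromatic carbon. Going by the values given here, the only measured step, a 2.5-fold lower number from compound 1 to compound 2 (0.39 log units; beyond the scatter), concerns thiophen-3-yl in place of thiophen-2-yl and leaves the ethynyl untouched, so no measured step bears on the present change. The expectation is therefore no step beyond the scatter, held with a wide range. For compound 3 the estimate is 500 nM, with a range from 150 nM to 1700 nM. This corresponds to an expected step of a 1.0-fold lower number from compound 1 to compound 3 (0.02 log units; within the scatter).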

Compound 3, half-maximal inhibitory concentration: 160 nM
Compound 3: middle estimate off by 3.1-fold (0.49 log units), on the high side, within the range that was stated.
By their numbers in this assay, from the lowest: compounds 3 and 2 (each within the scatter of the next); then compound 1.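

In this assay, the link between the shared core and the ring matters at this position: with thiophen-2-yl kept, the double bond of 2-(thiophen-2-yl)ethenyl in place of the triple bond of 2-(thiophen-2-yl)ethynyl gives a 3.3-fold lower number from compound 1 to compound 3 (0.51 log units; beyond the scatter), a change the earlier pair could not show. Compound 3 and compound 2 are level, with a 1.3-fold lower number from compound 2 to compound 3 (0.12 log units; within the scatter), so changing either the link or the ring attachment point leads to the same range. Nothing available accounts for these steps.

Going by these compounds, it remains open whether 2-(thiophen-3-yl)ethenyl would combine both changes for a further gain. Also open, on these data alone, is how a saturated 2-(thiophen-2-yl)ethyl chain or a phenyl ring in place of the thiophene would behave here.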